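The compounds below may be only part of what the source reports. "The series", "measured", "known", "first", "only" and "open" are said of these compounds alone.

Measured compounds:
compound 1 `C[C@@]12C[C@@H]1CC(COc1cccnc1Cl)N2` — > 10000 nM
compound 2 `Brc1ccc(OC[C@@H]2C[C@H]3C[C@H]3N2)cn1` — 46.5 nM

In an assay on CHO-K1 cells for displacement of a labelled ligand from Neuronal acetylcholine receptor; alpha4/beta2 (Homo sapiens), read by scintillation counting (a higher number here means a weaker inhibitor, a lower number a stronger inhibitor), compound 1 gives > 10000 nM. That figure is a limit of the assay, not a measured number, so compound 1 stands at the limit of > 10000 nM in this assay, at which 1 of the 2 values shown sits. Compound 2 `Brc1ccc(OC[C@@H]2C[C@H]3C[C@H]3N2)cn1` differs from compound 1 in more than one place, and in this assay compound 2 gives 46.5 nM. Compound 3 `C[C@@]12C[C@@H]1CC(COc1cccnc1)N2` is compound 1 with hydrogen in place of chloro on an aromatic carbon. Among the measured compounds shown here, no measured pair shows this single change, so its size cannot be read off. The step from compound 1 to compound 3 is expected to run toward stronger inhibition, by about an at least 3.3-fold lower number from compound 1 to compound 3 (0.52 log units; beyond the scatter). Compound 3 is estimated at 3000 nM, within 300 nM to 30000 nM.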

Compound 3, inhibition constant: 3.6 nM
Compound 3: middle estimate off by 830-fold (2.92 log units), on the high side; the measured number lies below the stated range.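

In this assay, putting hydrogen in place of chloro on this aromatic carbon, next to the ring nitrogen, gives an at least 2700-fold lower number from compound 1 to compound 3 (3.44 log units; beyond the scatter). A single atom at this position of the shared core therefore separates a very weak inhibitor from a strong one. The true step could be larger still, because compound 1 sits at a limit of the assay: the limit of > 10000 nM in this assay, at which 1 of the 3 values shown sits.

From the compounds shown here alone, only chloro and hydrogen are compared at this carbon, so how a fluoro, a methyl or an amine would behave there remains open. Going by these compounds, whether the same change has a similar effect on a different core also remains open.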